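The source may report more compounds than this note shows. Statements on the series, on what has been measured and on what is new or still open speak of the compounds shown alone.

In a functional assay on KB cells (Homo sapiens) for cytotoxicity (on this read-out lower numbers stand for stronger inhibition and higher numbers for weaker inhibition), compound 1 `CCC(O)C(=O)C[C@@H](C)CCC/C(C)=C\C=C\[C@]1(C)CCCc2ccoc21` gives < 1 ug/mL, which is a limit and not a number. Compound 2 `C/C(=C/C=C/[C@]1(C)CCCc2ccoc21)CCC[C@H](C)CC(=O)[C@@H](O)[C@H](C)Cl` gives < 1 ug/mL, also only a limit. Together these readings amount to the limit of < 1 ug/mL in this assay, at which 2 of the 2 values shown sit. Compound 3 `C/C(=C/C=C/[C@]1(C)CCCc2ccoc21)CCC[C@H](C)CC(=O)[C@H](O)[C@H](C)Cl` departs from compound 2 in one way: the two compounds have the same atoms and bonds and differ only in configuration as drawn: 1 of 6 stereo elements differ; a stereocentre at a saturated chain carbon is drawn R in compound 2 and S in compound 3. Among the compounds with values here, the only measured step, a step that the two limits leave unreadable from compound 1 to compound 2, has no size to carry over, so no step beyond the scatter is expected in this assay. The expected step is a step that the limit leaves unreadable from compound 2 to compound 3. For compound 3 the estimated value is 0.6 ug/mL, with an expected range from 0.15 ug/mL to 2.5 ug/mL.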

Compound 3, half-maximal inhibitory concentration: < 1 ug/mL
Compound 3: a limit, no number; the forecaster's own chance of this, stated with the estimate: 65%; the middle value is on the limit's open side.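

Within the data shown here, compound 1, compound 2 and compound 3 all give only limits, so no step among them can be read. Left open is how strong each is in this assay, and whether the stereocentre drawn differently in compound 2 and compound 3 matters.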